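The source may hold more compounds than are shown below. What is called first, only, known or untested is meant among the compounds shown, and "the series" means these compounds.

Compound 1, `CC(=O)c1c(C)nc2c(OCc3ccccc3)cccn12`, is one of two measured members of this series. In a functional assay on the whole organism with Rattus norvegicus as the target, with a stated time of 4 h, at a dose of 40 mg/kg by the intraperitoneal route (on this read-out higher numbers stand for more inhibition at the one dose given (going by the name of the read-out) and lower numbers for less inhibition), compound 1 gives 57%, the lower of the two numbers recorded. Among the compounds with values here, compound 2, `Cc1nc2c(OCc3ccccc3)cccn2c1Cl`, gives 93% in this assay, and the single measured step, a number 36 percentage points higher from compound 1 to compound 2 (beyond the scatter), replaces the acetyl group on an aromatic carbon with chloro.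

Compound 3, `Cc1nc2c(OCc3ccccc3)cccn2c1CC1=NCCN1`, has not yet been tested. Relative to compound 1 it shows (a group of 6 heavy atoms (4 carbon, 2 nitrogen; one five-membered non-aromatic ring with 2 hetero atoms) in place of a group of 3 heavy atoms (2 carbon, 1 oxygen; no ring), on an aromatic carbon). Within the data shown here, the only step that bears on this change is the one from compound 1 to compound 2, which also removed the acetyl group and was large. The group that enters here is a different one, so the size of the effect is uncertain, but the same direction is expected for compound 3 because the earlier removal gave a number 36 percentage points higher from compound 1 to compound 2 (beyond the scatter). Compound 3 is therefore estimated to show a number 18 percentage points higher from compound 1 to compound 3 (beyond the scatter), reaching about 75% in this assay, within a range of 45% to 95%.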

Compound 3, a percentage reported as inhibition, in the whole organism at one dose (the size of the read-out at that dose, not a potency): 69%
Beside the measured number, compound 3's estimate is 6 percentage points above it; the measured number falls inside the stated range.
By their numbers in this assay, from the lowest: compound 1; then compound 3; then compound 2.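

In this assay this aromatic carbon, two ring bonds from the ring nitrogen, gives a higher number with a second replacement for acetyl: there is a number 12 percentage points higher from compound 1 to compound 3 (beyond the scatter) with a much larger group that carries a five-membered non-aromatic ring with 2 hetero atoms. The gain from losing acetyl is thus not confined to chloro, yet its size depends on the group that enters, as there is a number 24 percentage points lower from compound 2 to compound 3 (beyond the scatter) when this group takes the place of the chlorine atom. No measurement at hand accounts for this order among the three groups.

The compounds shown leave open whether a simple amine, a carboxylic acid or a methyl group at this carbon would come closer to chloro or to acetyl. They also leave open whether the same order would hold at another dose or stated time.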